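This account rests on a few compounds, and the source may have more. Where it says the series, first, only, none or still open, it means among the compounds named here.

The measured compounds, all read in a functional assay on MGC-803 cells (Homo sapiens) for inhibition, read by sulforhodamine B assay; a lower number here means a stronger inhibitor, a higher number a weaker inhibitor:

Compound 1 `O=C1C(N2CCCC2)=CC(=O)c2c1nc1n2[C@H]2OC[C@@H](O)[C@H]2OC1` gives only a limit, > 16000 nM.
Compound 2 `O=C1C=C(Nc2ccc(C(F)(F)F)cc2)C(=O)c2c1nc1n2[C@H]2OC[C@@H](O)[C@H]2OC1` gives 2820 nM.
Compound 3 `O=C1C=C(N2CCCCC2)C(=O)c2c1nc1n2[C@H]2OC[C@@H](O)[C@H]2OC1` gives only a limit, > 8000 nM.

All three share one core and differ only in the group attached to a double-bonded ring carbon of that core. Among the compounds with values here, compound 1 carries a pyrrolidin-1-yl group there, and in this assay its value is a limit rather than a number, so where it stands among the three cannot be pinned down; it is one of two compounds whose results are limits (the limit of > 16000 nM in this assay, at which 1 of the 3 values shown sits), while compound 2, with an arylamino group, is the only one with a measured number.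

Compound 4 `O=C1C(Nc2cccc(Cl)c2)=CC(=O)c2c1nc1n2[C@H]2OC[C@@H](O)[C@H]2OC1` is the untested member of the set. It differs from compound 1 in a single place: (3-chlorophenyl)amino in place of pyrrolidin-1-yl on a double-bonded ring carbon. This change brings compound 4 closer in kind to compound 2, which also carries an arylamino group and gives a number rather than a limit. A move from compound 1 to compound 4 is therefore expected to run toward stronger inhibition, by an at least 4.5-fold lower number from compound 1 to compound 4 (0.66 log units; beyond the scatter). For compound 4 the estimated value in this assay is 3500 nM, expected to fall between 1000 nM and 12000 nM.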

Compound 4, half-maximal inhibitory concentration: 1530 nM
Compound 4: the middle estimate sits 2.3-fold (0.36 log units) above what was measured; low and high end bracket the measured number.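

In this assay, within the data shown here, this is the first change that can be read at a single place: on a double-bonded ring carbon, putting (3-chlorophenyl)amino in place of pyrrolidin-1-yl gives an at least 10-fold lower number from compound 1 to compound 4 (1.01 log units; beyond the scatter). The real size of this step could be larger still, because the result for compound 1 is a limit and not a number: the limit of > 16000 nM in this assay, at which 1 of the 4 values shown sits. Across the compounds shown, compound 2 and compound 4, which carry arylamino groups, give numbers, whereas compound 1 and compound 3, which carry non-aromatic rings attached through nitrogen, give only limits, and no compound goes against this split.

The step changes several things at once, since an aromatic ring enters, a chlorine enters and the nitrogen gains a hydrogen, so the compounds shown leave open which of these accounts for the stronger inhibition. A cyclohexylamino group would keep the hydrogen on the nitrogen without the aromatic ring, and a plain phenylamino group would keep the aromatic ring without the chlorine, so each would help to separate these contributions.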